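Geranyl polyamines: from compound 3 to compound 4

A few compounds are considered here, and "the series" means these few. Any claim that something is new, unique, unknown or untested is made for them only; others in the source may bear on it.

Read-outs in a toxicity assay on CHO cells (Cricetulus griseus) for cytotoxicity, read by WST assay, with a stated time of 24 h; a lower number here means a stronger inhibitor, a higher number a weaker inhibitor
- compound 1 `CC(C)=CCCC(C)=CCNCCN` gives 36200 nM
- compound 2 `CC(C)=CCCC(C)=CCNCCCN(C)CCCN` gives > 150000 nM (a limit, not a number)
- compound 3 `CCN(CC)CCCNCCCNCC=C(C)CCC=C(C)C` gives 30900 nM

Compound 3 (30900 nM) and compound 1 (36200 nM) lie within the scatter of each other, so the two numbers in hand sit together. Compound 2 is the only entry that stands as a limit (> 150000 nM).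

Compound 4 `CC(C)=CCCC(C)=CCNCCCNCCCCNCCCN` has not yet been measured. Relative to compound 3, it carries ((3-aminopropyl)amino)methyl in place of diethylamino on a saturated chain carbon, three bonds along the chain from an amine nitrogen.

Among the measured compounds shown here, no step between measured compounds that differ in one place is available, so the expectation rests on very little. Compound 2 also ends in a 3-aminopropyl group and reports a limit (> 150000 nM), which leans the expectation towards a higher number. A moderate move towards a weaker inhibitor is therefore expected, estimated as (a 2.3-fold higher number from compound 3 to compound 4 (0.36 log units; beyond the scatter)). For compound 4 the estimated value in this assay is (70000 nM), with an expected range from (20000 nM) to (150000 nM).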

Compound 4, half-maximal inhibitory concentration: > 150000 nM
Compound 4 gave a limit, no number (the forecaster's own chance of this, stated with the estimate: 25%); middle value at least 2.1-fold (0.33 log units) from the limit.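

In this assay, among the compounds shown here, ((3-aminopropyl)amino)methyl in place of diethylamino on a saturated chain carbon, three bonds along the chain from an amine nitrogen, gives an at least 4.8-fold higher number from compound 3 to compound 4 (0.68 log units; beyond the scatter), the first step that can be read between compounds differing in one place. Compound 4 stands at a limit, > 150000 nM, not a number, so only the lower bound of this step is known. Compound 2 and compound 4 both end in a 3-aminopropyl group, and no compound with that ending gives a number in this assay, a pairing that rests on these two compounds alone: the limit of > 150000 nM in this assay, at which 2 of the 4 values shown sit.

For the compounds shown here, the single change swaps the end group and extends the chain together, so this step cannot tell whether the terminal primary amine or the added ((3-aminopropyl)amino)methyl length accounts for the shift. A terminal dimethylamino group or a terminal acetamide on the chain of compound 4 would separate the two, and a value below the limit would give the step a measured size.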